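Lengthening a bromoalkoxy chain into a carboxylic acid

This account rests on a few compounds, and the source may have more. Where it says the series, first, only, none or still open, it means among the compounds named here.

Two compounds share one core and differ only in the chain carried on the ring oxygen. Compound 1 `O=c1c(-c2ccc(O)cc2)coc2cc(OCCCCBr)ccc12` gives 84.7% in a functional assay on mitochondria (Cricetulus griseus) for inhibition of Monoamine oxidase (Homo sapiens), tested at 3 uM (a higher number here means a stronger effect of the compound at the concentration tested, a lower number a weaker effect), and compound 2 `O=c1c(-c2ccc(O)cc2)coc2cc(OCCCBr)ccc12` gives 90.8%. The step of a number 6.1 percentage points higher from compound 1 to compound 2 (within the scatter) lies within the scatter, so compound 2 stands alongside compound 1 rather than apart from it.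

Compound 3 `O=C(O)CCCCCCCCCOc1ccc2c(=O)c(-c3ccc(O)cc3)coc2c1` has not yet been measured. Its change from compound 2 is 6-carboxyhexyl in place of bromo on a saturated chain carbon, three bonds along the chain from an oxygen on an aromatic ring. Going by the values given here, the only measured step, bromomethyl to bromo, was small and within the scatter, and it says nothing about a carboxylic acid entering at the end of a much longer chain. Such a change is therefore expected to carry real uncertainty, with a drop as plausible as no change. Compound 3 is expected to give 65%, within 30% to 92%. For compound 3 the expected step is a number 25.8 percentage points lower from compound 2 to compound 3 (beyond the scatter).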

Compound 3, a percentage reported as inhibition, at one concentration (the size of the read-out at that concentration, not a potency): 89.6%
Estimate against measurement, compound 3: 24.6 percentage points below, within the range that was stated.
By their numbers in this assay, from the lowest: compounds 1, 3 and 2 (each within the scatter of the next).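

Putting 6-carboxyhexyl in place of bromo gives a number 1.2 percentage points lower from compound 2 to compound 3 (within the scatter) in this assay, and putting 5-carboxypentyl in place of bromo gives a number 4.9 percentage points higher from compound 1 to compound 3 (within the scatter) in the same read-out. Going by these compounds alone, the earlier pair held only chains ending in bromine, so this is the first sign that the chain on the ring oxygen can end in a carboxylic acid, and be much longer, with the inhibition at this one concentration staying in the same range. Nothing measured here gives a reason for this.

All three compounds sit close together high on the scale, and the read-out shows only the size of the effect at this one concentration, so whether any of them would show a stronger or weaker effect at another concentration stays hidden. From the compounds shown here alone, whether the same holds for an amine or an ester at the chain end, or for a shorter chain carrying the carboxylic acid, stays open.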